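The compounds below may be only part of what the source reports. "The series", "measured", "known", "first", "only" and "open" are said of these compounds alone.

Measured so far:
- compound 1 `N=C(Nc1cccc(C(F)(F)F)c1)c1cc2c(-c3ccccc3)n[nH]c2cn1`: 19900 nM
- compound 2 `COc1ccc(Cn2nc(-c3ccccc3)c3cc(C(=N)Nc4ccccc4)ncc32)cc1`: 6300 nM

Two compounds of this series have been run in a functional assay on PC-3 cells (Homo sapiens) for cytotoxicity, read by MTT assay, with a stated time of 72 h; on this read-out lower numbers stand for stronger inhibition and higher numbers for weaker inhibition. Compound 1 gives 19900 nM. Compound 2 gives 6300 nM, the lowest of the two numbers; compound 1 is the nearest and stands beyond the usual scatter from it. For the measured compounds named here, compound 1 and compound 2 differ from one another in more than one place, so no single structural step joins them and nothing can be read from that pair about any one change.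

Compound 3 `COc1ccc(Cn2nc(-c3ccccc3)c3cc(C(=N)Nc4cccc(C(F)(F)F)c4)ncc32)cc1` is not yet measured. It derives from compound 2 by the change trifluoromethyl in place of hydrogen on an aromatic carbon, on the six-membered aromatic ring of carbon only, meta to a large group. Going by the values given here, there is no measured pair that isolates this change, and the two numbers in hand give no direction for it. The expectation is therefore a step of modest size, a 1.3-fold higher number from compound 2 to compound 3 (0.10 log units; within the scatter), with no clear direction and possibly none beyond the scatter. For compound 3 the estimate in this assay is 8000 nM, within a range of 2500 nM to 25000 nM.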

Compound 3, half-maximal inhibitory concentration: > 50000 nM
Compound 3: no number, only a limit (the forecaster's own chance of this, stated with the estimate: 5%); middle value at least 6.2-fold (0.79 log units) away from the limit.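

In this assay compound 3 yields no number, only a limit: the limit of > 50000 nM in this assay, at which 1 of the 3 values shown sits.

For the compounds shown here, this gives the first reading of a single change on the anilino ring: trifluoromethyl in place of hydrogen on an aromatic carbon, meta to a large group, is not a neutral swap with the 4-methoxybenzyl group present, and it gives an at least 7.9-fold higher number from compound 2 to compound 3 (0.89 log units; beyond the scatter). With the trifluoromethyl held constant, 4-methoxybenzyl in place of hydrogen on an aromatic nitrogen gives an at least 2.5-fold higher number from compound 1 to compound 3 (0.40 log units; beyond the scatter), so compound 3, which carries both groups, reads weaker than either compound carrying only one of them, a combination that the unconnected pair of compound 1 and compound 2 could not reveal.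

Still open, from the compounds shown here alone, is how a fluorine, a methyl or an amine at the same place on the anilino ring would read with the 4-methoxybenzyl group present, and whether any group there keeps the activity of compound 2. Going by these compounds, the true size of both steps also remains open, since each rests on a limit rather than on a number.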